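This account rests on a few compounds, and the source may have more. Where it says the series, first, only, none or still open, it means among the compounds named here.

Measured so far in a functional assay on HCT-116 cells (Homo sapiens) for antiproliferative activity, read by MTT assay, with a stated time of 48 h; a lower number here means a stronger inhibitor, a higher number a weaker inhibitor:
- compound 1 `COc1cc(-c2nnc(SCC(=O)c3ccccc3)n2N)cc(OC)c1OC`, compound 1 gives 53000 nM
- compound 2 `COc1cc(-c2nnc(SCC(=O)c3ccc(Br)cc3)n2N)cc(OC)c1OC`, compound 2 gives 9230 nM
- compound 3 `COc1cc(-c2nnc(SCC(=O)c3cccc(Br)c3)n2N)cc(OC)c1OC`, compound 3 gives 5320 nM

Compound 2 holds the second highest number of the three. Its nearest neighbour is compound 3, a 1.7-fold lower number from compound 2 to compound 3 (0.24 log units; within the scatter), so the two cannot be told apart. The larger gap is to compound 1, a 5.7-fold lower number from compound 1 to compound 2 (0.76 log units; beyond the scatter), and the parallel a 10-fold lower number from compound 1 to compound 3 (1.00 log units; beyond the scatter) points the same way: adding a bromo lowers the number beyond the scatter in both cases.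

Compound 4 `COc1cc(-c2nnc(SCC(=O)Nc3ccccc3F)n2N)cc(OC)c1OC` differs from compound 2 as follows: (2-fluorophenyl)amino in place of 4-bromophenyl on a carbonyl carbon. Among the measured compounds shown here, no measured step covers this change. Going by these compounds, the measured steps only show that losing the bromo, as in compound 1 against compound 2, raises the number; what the entering (2-fluorophenyl)amino adds is unknown here. An increase of the kind seen from compound 2 toward compound 1 is therefore expected, wide in uncertainty: a 2.4-fold higher number from compound 2 to compound 4 (0.38 log units; beyond the scatter). For compound 4 the estimate in this assay is 22000 nM, within 5000 nM to 90000 nM.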

Compound 4, half-maximal inhibitory concentration: 1160 nM
Compound 4: the middle estimate sits 19-fold (1.28 log units) above what was measured; measured number outside the range, below it.
By their numbers in this assay, from the lowest: compound 4; then compounds 3 and 2 (each within the scatter of the next); then compound 1.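

In this assay, the carbonyl carbon carrying the saturated chain proves a productive place for change: (2-fluorophenyl)amino gives an 8.0-fold lower number from compound 2 to compound 4 (0.90 log units; beyond the scatter) and a 4.6-fold lower number from compound 3 to compound 4 (0.66 log units; beyond the scatter), both beyond the scatter, and the step from the unsubstituted phenyl is larger still, a 46-fold lower number from compound 1 to compound 4 (1.66 log units; beyond the scatter). A bromo is therefore not needed for a low number in this series, as compound 4 carries none and has the lowest number of the four, beyond the scatter of each of the others. No measurement at hand accounts for this drop.

The change from (4-bromophenyl)carbonyl to (2-fluorophenyl)carbamoyl alters the amino nitrogen and the ring fluorine together, so the share of each remains unresolved. Also open, going by these compounds, is whether a plain phenylamino, a (4-bromophenyl)amino or a methylamino group on the same carbonyl carbon would hold the number as low.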